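The source may report more compounds than this note shows. Statements on the series, on what has been measured and on what is new or still open speak of the compounds shown alone.

Working notes on the alkynyl series.

Compound 1 `C#Cc1cn(C2O[C@H](CO)[C@@H](O)[C@@H]2O)c(=O)[nH]c1=O` carries an ethynyl group on the aromatic carbon of the shared core and bears the ribose sugar; in a functional assay on L1210 cells (Mus musculus) (a lower number here means a stronger inhibitor, a higher number a weaker inhibitor), compound 1 gives 45 ug/mL. Compound 2 `CC#CCc1cn([C@H]2C[C@H](O)[C@@H](CO)O2)c(=O)[nH]c1=O` is the deoxyribose member with a but-2-yn-1-yl group on that carbon. In this assay compound 2 returns only a limit, > 1000 ug/mL, not a number. That value is the limit of > 1000 ug/mL in this assay, at which 1 of the 3 values shown sits. Compound 3 `Cc1ccc(S(=O)(=O)OCCC#Cc2cn([C@H]3C[C@H](O)[C@@H](CO)O3)c(=O)[nH]c2=O)cc1` carries a tosylated alkynyl chain on the same aromatic carbon. In this assay compound 3 likewise returns only a limit, > 200 ug/mL. That value is the limit of > 200 ug/mL in this assay, at which 1 of the 3 values shown sits. Among the compounds with values here, compound 2 therefore stands at the far limit of the series: its value is one of two limits, and no step between two measured compounds with a single structural difference can be drawn from these three results.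

Compound 4 `COCC#Cc1cn([C@H]2C[C@H](O)[C@@H](CO)O2)c(=O)[nH]c1=O` has not yet been measured in this assay. The change from compound 2 is 3-methoxyprop-1-yn-1-yl in place of but-2-yn-1-yl on an aromatic carbon. Within the data shown here, with compound 2 fixed only by a limit, no measured step sets the expectation, and the estimate is therefore wide. The step from compound 2 to compound 4 is expected to be toward a stronger inhibitor, an at least 3.3-fold lower number from compound 2 to compound 4 (0.52 log units; beyond the scatter), beyond the scatter but uncertain in size. Compound 4 is estimated at 300 ug/mL, within 50 ug/mL to 1000 ug/mL, with a real chance that only a limit is reported.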

Compound 4, concentration for 50% inhibition: 254 ug/mL
The estimate for compound 4 lay 1.2-fold (0.07 log units) above the measured number; the measured number falls inside the stated range.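

Within the data shown here, compound 4 is the first deoxyribose member here to return a number rather than a limit in this assay, which shows that inhibition can be read with a chain on this aromatic carbon of the shared core. Placing 3-methoxyprop-1-yn-1-yl in place of but-2-yn-1-yl gives an at least 3.9-fold lower number from compound 2 to compound 4 (0.59 log units; beyond the scatter), the first step in the series that can be read, and it lies beyond the usual scatter. The true size of this step remains unknown, and the printed size is only a floor, because compound 2 is fixed by a limit and not by a number: the limit of > 1000 ug/mL in this assay, at which 1 of the 4 values shown sits.

The compounds shown do not separate the added oxygen of the 3-methoxyprop-1-yn-1-yl group from the different placing of the triple bond within the chain, since both arrive in one change. A but-1-yn-1-yl chain would isolate the oxygen, while a terminal hydroxyl or amine in place of the methoxy, or a longer chain, would show how far this position tolerates further change.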